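The source may report more compounds than this note shows. Statements on the series, on what has been measured and on what is new or still open speak of the compounds shown alone.

Compound 1 `CCCCCCNc1nc(SCc2ccc(C(F)(F)F)cc2)nc2ccccc12` gives 23900 nM in a functional assay on HGC-27 cells (Homo sapiens) for cytotoxicity, read by MTT assay, with a stated time of 72 h; a lower number here means a stronger inhibitor, a higher number a weaker inhibitor. Compound 2 `FC(F)(F)c1ccc(CSc2nc(Nc3ccccc3C(F)(F)F)c3ccccc3n2)cc1` gives only > 50000 nM in this assay, and that is a limit of the assay rather than a number. Compound 3 `FC(F)(F)c1ccc(CSc2nc(Nc3cccc(Br)c3)c3ccccc3n2)cc1` gives 18300 nM in this assay.

Compound 2 thus sits at the limit of > 50000 nM in this assay, at which 1 of the 3 values shown sits, the highest of the three. Compound 4 `COc1cc(Nc2nc(SCc3ccc(C(F)(F)F)cc3)nc3ccccc23)cc(OC)c1` differs from compound 2 in one place: 3,5-dimethoxyphenyl in place of 2-(trifluoromethyl)phenyl on a nitrogen on an aromatic ring. Going by the values given here, the measured step closest to this change is the one that also swaps the same group for another aryl group, an at least 2.7-fold lower number from compound 2 to compound 3 (0.43 log units; beyond the scatter); the move onto that group from hexyl was an at least 2.0-fold higher number from compound 1 to compound 2 (0.32 log units; beyond the scatter). Both put 2-(trifluoromethyl)phenyl at the higher number, so for compound 4 a lower number is expected, roughly an at least 2.5-fold lower number from compound 2 to compound 4 (0.39 log units; beyond the scatter). Compound 4 is therefore estimated at 20000 nM, within 8000 nM to 50000 nM.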

Compound 4, half-maximal inhibitory concentration: > 50000 nM
Compound 4: no number, only a limit (the forecaster's own chance of this, stated with the estimate: 25%); middle value at least 2.5-fold (0.39 log units) from the limit.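

Compound 4 gives only a limit and not a number in this assay: the limit of > 50000 nM in this assay, at which 2 of the 4 values shown sit. Of the three aryl groups shown on this nitrogen, 3-bromophenyl alone gives a measured number, and changing it to 3,5-dimethoxyphenyl gives an at least 2.7-fold higher number from compound 3 to compound 4 (0.43 log units; beyond the scatter), while replacing hexyl gives an at least 2.0-fold higher number from compound 1 to compound 4 (0.32 log units; beyond the scatter). The step between the two compounds at the limit cannot be read, so 3,5-dimethoxyphenyl and 2-(trifluoromethyl)phenyl cannot be ranked.

From the compounds shown here alone, it remains open whether 4-bromophenyl, 3-methoxyphenyl or a butyl chain on this nitrogen would give a measured number in this assay.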